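Aryl Substituent Changes on the Shared Core

The compounds below may be only part of what the source reports. "The series", "measured", "known", "first", "only" and "open" are said of these compounds alone.

Measured compounds in a functional assay on PANC-1 cells (Homo sapiens) for antiproliferative activity, read by CCK-8 assay, with a stated time of 72 h; on this read-out lower numbers stand for stronger inhibition and higher numbers for weaker inhibition:
compound 1, `Cc1cc(Nc2cc(N3CCN(C)CC3)nc(Nc3ccc(S(N)(=O)=O)cc3)n2)n[nH]1`, 8760 nM
compound 2, `Cc1cc(Nc2cc(N3CCN(C)CC3)nc(Nc3ccc([N+](=O)[O-])cc3)n2)n[nH]1`, 442 nM
compound 3, `COc1cccc(Nc2nc(Nc3cc(C)[nH]n3)cc(N3CCN(C)CC3)n2)c1`, 693 nM

Compound 2 has the lowest number of the three in this assay. Its gap to compound 3 is a 1.6-fold higher number from compound 2 to compound 3 (0.20 log units; within the scatter), so the two cannot be ordered; the step of a 20-fold lower number from compound 1 to compound 2 (1.30 log units; beyond the scatter) is well beyond the scatter, and compound 3 likewise stands apart from compound 1 by a 13-fold lower number from compound 1 to compound 3 (1.10 log units; beyond the scatter). The pair of steps from compound 1 shows that the group on the aryl ring can shift the number a great deal, while the comparison of compound 2 with compound 3 shows that nitro and methoxy, placed differently on that ring, give numbers of the same order.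

Compound 4, `COc1ccc(Nc2nc(Nc3cc(C)[nH]n3)cc(N3CCN(C)CC3)n2)cc1`, is the next step from compound 2: methoxy in place of nitro on an aromatic carbon. Read one bond further out, this is 4-nitrophenyl to 4-methoxyphenyl. Within the data shown here, no measured step replaces nitro by methoxy at the same position; the closest guide is compound 3, whose methoxy sits at another position and which lies within the scatter of compound 2. A small step, if any, is therefore expected, with the number more likely to rise than fall, estimated as a 2.0-fold higher number from compound 2 to compound 4 (0.31 log units; beyond the scatter).

Compound 4 is expected to give 900 nM, within 300 nM to 3000 nM.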

Compound 4, half-maximal inhibitory concentration: 1120 nM
Compound 4: middle estimate off by 1.2-fold (0.09 log units), on the low side; the measured number falls inside the stated range.
By their numbers in this assay, from the lowest: compounds 2, 3 and 4 (each within the scatter of the next, the first and the last beyond it); then compound 1.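

Among these compounds, replacing nitro with methoxy within the 4-substituted aryl group gives a 2.5-fold higher number from compound 2 to compound 4 (0.40 log units; beyond the scatter) in this assay, the first comparison of these two groups at one ring position, and this modest step lies beyond the scatter, which the earlier comparison with methoxy at another position did not show. Replacing 3-methoxyphenyl with 4-methoxyphenyl gives a 1.6-fold higher number from compound 3 to compound 4 (0.21 log units; within the scatter), so these compounds do not separate the two methoxy placements on the ring. Methoxy in place of sulfamoyl gives a 7.8-fold lower number from compound 1 to compound 4 (0.89 log units; beyond the scatter) as a third large-to-modest drop from compound 1, so all three replacements shown for the 4-sulfamoylphenyl group lower the number beyond the scatter, and none of them goes against this pattern.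

Still open, from the compounds shown here alone, is how an amine, a carboxylic acid or a chlorine atom at this same ring position would compare with nitro and methoxy, and whether nitro at the ring position of the methoxy in compound 3 would give a number close to that of compound 2. No evidence is at hand that gives a reason for any of these steps.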